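A Methoxy Group on the Anilino Ring of Compound 1

A few compounds are considered here, and "the series" means these few. Any claim that something is new, unique, unknown or untested is made for them only; others in the source may bear on it.

Compound 1 `FC(F)(F)c1ccc(CSc2nc(Nc3ccccc3)c3ccccc3n2)cc1` is the starting point. In a functional assay on MCF7 cells (Homo sapiens) for cytotoxicity, read by MTT assay, with a stated time of 72 h (on this read-out lower numbers stand for stronger inhibition and higher numbers for weaker inhibition), compound 1 gives 44000 nM, the highest of the two numbers shown. Its nearest neighbour is compound 3 `FC(F)(F)c1ccc(CSc2nc(Nc3cccc(Br)c3)c3ccccc3n2)cc1`, which in this assay gives 25600 nM; the step is a 1.7-fold lower number from compound 1 to compound 3 (0.24 log units; within the scatter). Compound 2 `FC(F)(F)c1ccc(CSc2nc(Nc3ccccc3Cl)c3ccccc3n2)cc1` gives > 50000 nM in this assay, and this is a limit of the assay rather than a number, (the limit of > 50000 nM in this assay, at which 1 of the 3 values shown sits).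

Compound 4 `COc1ccc(Nc2nc(SCc3ccc(C(F)(F)F)cc3)nc3ccccc23)cc1` is not yet measured. It differs from compound 1 by methoxy in place of hydrogen on an aromatic carbon. Going by the values given here, two measured steps bear on this change, both also replacing a hydrogen on an aromatic carbon of compound 1 with a small group: an at least 1.1-fold higher number from compound 1 to compound 2 (0.05 log units; that floor lies within the scatter) and a 1.7-fold lower number from compound 1 to compound 3 (0.24 log units; within the scatter). Neither moved beyond the scatter, so no step beyond the scatter in this assay is expected for compound 4, in either direction, while the nearby limit of compound 2 leaves open that only a limit is reported. Compound 4 is therefore expected to give about 40000 nM in this assay, with a range from 18000 nM to 90000 nM. This estimate means an expected step of a 1.1-fold lower number from compound 1 to compound 4 (0.04 log units; within the scatter).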

Compound 4, half-maximal inhibitory concentration: 47200 nM
For compound 4 the middle estimate is 1.2-fold (0.07 log units) below the measured one; measured number inside the range.
By their numbers in this assay, from the lowest: compounds 3, 1 and 4 (each within the scatter of the next). At a limit, above all of these: compound 2.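

Methoxy in place of hydrogen, para to a large group on the anilino ring, is the first change here to bring in an oxygen, and in this assay the step is a 1.1-fold higher number from compound 1 to compound 4 (0.03 log units; within the scatter). Setting 4-methoxyphenyl against 3-bromophenyl on the same nitrogen gives a 1.8-fold higher number from compound 3 to compound 4 (0.27 log units; within the scatter), so the two groups, which differ in their atoms and in where they sit on the ring, cannot be told apart in this assay. Compound 2 stands at a limit of the assay and not at a number: the limit of > 50000 nM in this assay, at which 1 of the 4 values shown sits. From that limit the step can be given only as a floor, as an at least 1.0-fold lower number from compound 2 to compound 4 (0.02 log units; that floor lies within the scatter).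

On these data alone, what stays open is whether a different kind of group at this position, such as an amine, a carboxylic acid or a longer chain ending in an oxygen-linked alkyl group, would move the number beyond the scatter. The compounds shown also all keep the same trifluoromethyl-bearing benzyl group and the same core, so they say nothing about how the number responds to a change there, for instance a nitrile in place of trifluoromethyl.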